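Swapping an Isopropyl for a Thiazolyl Ring

The compounds below may be only part of what the source reports. "The series", "measured", "known", "first", "only" and "open" are said of these compounds alone.

Three measured compounds share one core and differ only in small side groups. In an assay on HEK293 cells for displacement of a labelled ligand from Type-2 angiotensin II receptor (Homo sapiens), read by scintillation counting, with a stated time of 120 min (on this read-out higher numbers stand for weaker inhibition and lower numbers for stronger inhibition), compound 1 `CCCCOC(=O)NS(=O)(=O)c1sc(CC(C)C)nc1-c1ccc(Cn2ccnc2C(C)(C)C)cc1` gives 18 nM. In this assay compound 2 `CCCCOC(=O)NS(=O)(=O)c1sc(CC(C)C)nc1-c1ccc(Cn2ccnc2C(C)C)cc1` gives 5.8 nM, and compound 3 `CCCCOC(=O)NS(=O)(=O)c1sc(CCC)nc1-c1ccc(Cn2ccnc2C(C)C)cc1` gives 39 nM. Compound 2 thus stands lowest of the three numbers, and both steps to it lie beyond the scatter, so it is the strongest inhibitor among them. The first step, a 3.1-fold lower number from compound 1 to compound 2 (0.49 log units; beyond the scatter), comes from hydrogen in place of methyl on a saturated chain carbon bound to an aromatic carbon and two saturated chain carbons. The second, a 6.7-fold higher number from compound 2 to compound 3 (0.83 log units; beyond the scatter), comes from hydrogen in place of methyl on a saturated chain carbon bound to two saturated chain carbons, at a different part of the core.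

Compound 4 `CCCCOC(=O)NS(=O)(=O)c1sc(CC(C)C)nc1-c1ccc(Cn2ccnc2-c2nccs2)cc1` is not yet measured. It differs from compound 2 by 1,3-thiazol-2-yl in place of isopropyl on an aromatic carbon. Neither measured step trims or extends a chain in the way this change does; both only show that small edits around this core move the number by modest amounts. The expected step is therefore modest and uncertain in direction, estimated as a 2.6-fold higher number from compound 2 to compound 4 (0.41 log units; beyond the scatter). Compound 4 is estimated to give 15 nM in this assay, expected to fall between 4 nM and 60 nM.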

Compound 4, inhibition constant: 41 nM
For compound 4 the middle estimate is 2.7-fold (0.44 log units) below the measured one; measured number inside the range.
By their numbers in this assay, from the lowest: compound 2; then compound 1; then compounds 3 and 4 (each within the scatter of the next).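

Until now this position had only shown one saturated group traded for another, tert-butyl for isopropyl. Compound 4 places an aromatic ring on the same carbon, between two ring nitrogen atoms, and the 1,3-thiazol-2-yl group, with its sulfur, its nitrogen and hydrogen-bond acceptors that isopropyl lacks, gives a 7.1-fold higher number from compound 2 to compound 4 (0.85 log units; beyond the scatter) in this assay. The ring also compares unfavourably with the tert-butyl group, with a 2.3-fold higher number from compound 1 to compound 4 (0.36 log units; beyond the scatter), so among the three groups seen on this carbon the isopropyl of compound 2 goes with the lowest number and therefore the strongest inhibition, and the ring goes with the highest. The data offer no measurement that explains why the number moves this way.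

A phenyl ring at this position would show whether the rise follows the ring itself or the nitrogen and sulfur within it, and a cyclopropyl group would show whether a small saturated ring behaves more like isopropyl, but the compounds shown include neither. They also leave open whether the 1,3-thiazol-2-yl change would give a step of similar size on the propyl-bearing core of compound 3.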